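The source may hold more compounds than are shown below. What is called first, only, known or untested is meant among the compounds shown, and "the series" means these compounds.

Compound 1 `CC1=C(C(=O)NC(C)C)C(c2ccoc2)NC(=O)N1` is the starting point of this account. Among the compounds with values here, in an assay on membranes from CHO cells for displacement of a labelled ligand from adenosine receptor A1 (Homo sapiens), read by scintillation counting, with a stated time of 60 min, tested at 1 uM (a lower number here means less inhibition, a higher number more inhibition at the concentration tested (going by the name of the read-out)), compound 1 gives 1%, the lowest of the three numbers measured so far. Compound 2 `CC1=C(C(=O)NC(C)C)C(c2ccsc2)NC(=O)N1` gives 8%, and the change a number 7 percentage points higher from compound 1 to compound 2 (within the scatter) lies within the scatter. Compound 3 `CC1=C(c2ncc(C)o2)C(c2ccoc2)NC(=O)N1` gives 21%, and the step of a number 20 percentage points higher from compound 1 to compound 3 (beyond the scatter) is the only one beyond the scatter.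

Compound 4 `CC1=C(C(=O)OCC2CCC2)C(c2ccoc2)NC(=O)N1` differs from compound 1 at the carbonyl carbon: cyclobutylmethoxy in place of isopropylamino on a carbonyl carbon. Within the data shown here, of the two measured steps, the one from compound 1 to compound 3 touches the same part of the molecule, since it also replaces the isopropylcarbamoyl group, and it gave a modest rise; the step to compound 2 alters another place and changed little. Among the measured compounds shown here, neither step is the same exchange as the one to compound 4, so only a small upward move, if any, is expected here, a number 9 percentage points higher from compound 1 to compound 4 (within the scatter). Compound 4 is therefore expected to give about 10%, within a range from 0% to 30%.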

Compound 4, a percentage reported as inhibition, at one concentration (the size of the read-out at that concentration, not a potency): 46%
Compound 4: middle estimate off by 36 percentage points, on the low side, outside the stated range (above it).
By their numbers in this assay, from the lowest: compounds 1 and 2 (each within the scatter of the next); then compound 3; then compound 4.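

In this assay, within the data shown here, cyclobutylmethoxy on this carbonyl carbon gives a number 45 percentage points higher from compound 1 to compound 4 (beyond the scatter), a large step, whereas the only earlier change at this part of the molecule, which replaced the whole isopropylcarbamoyl group, gave the modest a number 20 percentage points higher from compound 1 to compound 3 (beyond the scatter). The exchange at this position does several things at once: the hydrogen-bond donor of isopropylamino leaves, a hydrogen-bond acceptor enters, the group grows from 4 to 6 heavy atoms, and a four-membered ring of carbon appears. No measurement at hand accounts for the rise.

Which of these differences carries the step remains open, as they all arrive together in compound 4. An isopropoxy group or a cyclobutylmethylamino group on the same carbonyl carbon would separate the effect of the ring from that of the oxygen link.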